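Carboxylic acid restored on the amine-linked aryl group

The source may hold more compounds than are shown below. What is called first, only, known or untested is meant among the compounds shown, and "the series" means these compounds.

Measured so far in an assay on isolated protein for activation of cGMP-dependent protein kinase 1 (Homo sapiens), read by ADP-Glo, with stated times of 120 min and 40 min; a lower number here means that less compound is needed, a higher number that more compound is needed for the effect:
compound 1 `O=C(O)c1ccc(CN2CCC[C@H](OCc3cc(Cl)cc(Cl)c3)[C@@H]2c2ccccc2)s1` gives 76000 nM.
compound 2 `Clc1cc(Cl)cc(CO[C@H]2CCCN(Cc3ccncc3)[C@H]2c2ccccc2)c1` gives only a limit, > 200000 nM.

Compound 2 thus stands at the limit of this assay (the limit of > 200000 nM in this assay, at which 1 of the 2 values shown sits), with no number. Compound 3 `O=C(O)c1ccc(CN2CCC[C@H](OCc3cc(Cl)cc(Cl)c3)[C@@H]2c2ccccc2)cn1` differs from compound 2 by 6-carboxypyridin-3-yl in place of pyridin-4-yl on a saturated chain carbon bound to an amine nitrogen in a ring. For the measured compounds named here, the one measured step that bears on this runs the opposite way, an at least 2.6-fold higher number from compound 1 to compound 2 (0.42 log units; beyond the scatter), where 5-carboxythiophen-2-yl gave way to pyridin-4-yl. Putting a carboxylic acid back is expected to lower the number, by an estimated at least 2.5-fold lower number from compound 2 to compound 3 (0.39 log units; beyond the scatter). Compound 3 is therefore expected at 80000 nM in this assay, with a range from 30000 nM to 250000 nM.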

Compound 3, half-maximal effective concentration: > 200000 nM
Compound 3 ended at the assay's limit (the forecaster's own chance of this, stated with the estimate: 35%); at least 2.5-fold (0.39 log units) between middle value and limit.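

In this assay, a carboxylic acid on the amine-linked aryl group is not enough by itself: 6-carboxypyridin-3-yl in place of 5-carboxythiophen-2-yl gives an at least 2.6-fold higher number from compound 1 to compound 3 (0.42 log units; beyond the scatter). The step from pyridin-4-yl to 6-carboxypyridin-3-yl cannot be read, so any gain from the acid on the pyridine ring stays hidden, and most of the series now sits at the ceiling: the limit of > 200000 nM in this assay, at which 2 of the 3 values shown sit.

As far as these compounds go, whether the 5-carboxythiophen-2-yl advantage comes from the ring or from where the acid sits remains open. A 4-carboxyphenyl group or a carboxylic acid on a longer chain at this place would separate the two.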